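The source may report more compounds than this note shows. Statements on the series, on what has been measured and on what is new or still open speak of the compounds shown alone.

In a functional assay on MCF7 cells (Homo sapiens) for antiproliferative activity, read by MTT assay, with a stated time of 48 h (a lower number here means a stronger inhibitor, a higher number a weaker inhibitor), compound 3 `COc1ncc(-c2ccc3nc(NC(C)=O)nn3c2)cc1NS(=O)(=O)c1ccc(C)cc1` gives 810 nM, level within the scatter with compound 2 `COc1ncc(-c2ccc3nc(NC(C)=O)nn3c2)cc1NS(=O)(=O)c1ccc(F)cc1` at 840 nM. Compound 1 `CC(=O)Nc1nc2ccc(-c3cnc(Cl)c(NS(=O)(=O)c4ccc(C)cc4)c3)cn2n1` stands clearly higher at 3250 nM. Next is compound 4 `COc1ncc(-c2ccc3nc(NC(C)=O)nn3c2)cc1NS(=O)(=O)c1ccc(C2CC2)cc1`, with cyclopropyl in place of methyl on an aromatic carbon, 4-methylphenyl to 4-cyclopropylphenyl. Within the data shown here, the nearest precedent is the change of methyl in place of fluoro at that same carbon, a 1.0-fold lower number from compound 2 to compound 3 (0.02 log units; within the scatter). The other measured step, a 4.0-fold lower number from compound 1 to compound 3 (0.60 log units; beyond the scatter), is methoxy in place of chloro, elsewhere in the molecule, and says little here. No step beyond the scatter is therefore expected in this assay. The estimated step is a 1.1-fold lower number from compound 3 to compound 4 (0.03 log units; within the scatter). For compound 4 the expected value is 750 nM, within a range of 300 nM to 1900 nM.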

Compound 4, half-maximal inhibitory concentration: 1640 nM
Beside the measured number, compound 4's estimate is 2.2-fold (0.34 log units) below it, and the stated range covers the measured number.
By their numbers in this assay, from the lowest: compounds 3, 2, 4 and 1 (each within the scatter of the next, the first and the last beyond it).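

In this assay, among these compounds, cyclopropyl is the first group at this aromatic carbon to separate from another: a 2.0-fold higher number from compound 3 to compound 4 (0.31 log units; beyond the scatter) lies beyond the scatter, though modest, while a 2.0-fold higher number from compound 2 to compound 4 (0.29 log units; within the scatter) stays within it. The carbon is therefore not wholly indifferent to its group, but the shift is small and is read clearly only against methyl. No evidence at hand accounts for this shift.

As far as these compounds go, whether tert-butyl, a longer chain or an amine at this carbon would move the number further remains open. So does whether the cyclopropyl step holds with chloro in place of methoxy.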